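Chain length at the acid of the bis-phenol series

The compounds below may be only part of what the source reports. "The series", "measured", "known", "first", "only" and "open" are said of these compounds alone.

Measured so far in a functional assay on ileum (Cavia porcellus) for inhibition of cysteinyl leukotriene receptor (Homo sapiens); a lower number here means a stronger inhibitor, a higher number a weaker inhibitor: compound 1 `CCCc1c(OCCCOc2c(C(C)=O)ccc(OCCCC(=O)O)c2CCC)ccc(C(C)=O)c1O` gives 200 nM; compound 2 `CCCc1c(OCCCOc2c(C(C)=O)ccc(OCCCCCC(=O)O)c2CCC)ccc(C(C)=O)c1O` gives 1000 nM; compound 3 `CCCc1c(OCCCOc2ccc3ccc(OCC(=O)O)cc3c2)ccc(C(C)=O)c1O` gives 300 nM.

Among the compounds with values here, the one counted step, (2-carboxyethyl in place of carboxy on a saturated chain carbon, three bonds along the chain from an oxygen on an aromatic ring), made a 5.0-fold higher number from compound 1 to compound 2 (0.70 log units; beyond the scatter). Compound 3 stands within the scatter of compound 1; the difference between the two cores is not broken down here.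

Compound 4 `CCCc1c(OCCCOc2ccc3ccc(OCCCC(=O)O)cc3c2)ccc(C(C)=O)c1O` is not yet measured. It carries the same kind of change as compound 2, (2-carboxyethyl in place of carboxy on a saturated chain carbon bound to an oxygen on an aromatic ring), but at a chain carbon bound to the oxygen rather than three bonds along the chain from it. Within the data shown here, the chain compound 4 gains is the one compound 1 already bears at 200 nM, so a smaller step than the earlier one is expected, a 1.7-fold higher number from compound 3 to compound 4 (0.22 log units; within the scatter), in this assay. Compound 4 is estimated at 500 nM, between 150 nM and 1500 nM.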

Compound 4, half-maximal inhibitory concentration: 5000 nM
The estimate for compound 4 lay 10-fold (1.00 log units) below the measured number, and the stated range ends below it.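

In this assay the new step is a 17-fold higher number from compound 3 to compound 4 (1.22 log units; beyond the scatter) and so the longer acid chain gives a higher number on both cores, but the size of the change does not carry from one core to the other: the same change on two cores in this assay, a 5.0-fold higher number (0.70 log units; beyond the scatter) from compound 1 to compound 2 and a 17-fold higher number (1.22 log units; beyond the scatter) from compound 3 to compound 4, 3.3-fold (0.52 log units) apart, beyond the scatter of two such steps. The two steps also start from different chain lengths, one on the carbon bound to the aromatic oxygen and the other three bonds along the chain, so the role of the core is not separated from that of the starting chain. Two pairs give no rule for any further core.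

Still open, from the compounds shown here alone, is how the core of compound 1 behaves with a carboxymethoxy chain, and how the core of compound 3 behaves at an intermediate chain length. Also open, going by these compounds, is whether a tetrazole in place of the carboxylic acid would follow either trend.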